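The source may hold more compounds than are shown below. What is called first, only, known or untested is meant among the compounds shown, and "the series" means these compounds.

Going by these compounds, compound 3 `COC(=O)CCCNC(=O)CN1CN(c2ccccc2)C2(CCN(C(=O)c3ccc(C(C)(C)C)cc3)CC2)C1=O` has no number in an assay on HEK293 cells for displacement of a labelled ligand from NPC1-like intracellular cholesterol transporter 1 (Homo sapiens); on this read-out lower numbers stand for stronger inhibition and higher numbers for weaker inhibition: its result is given as "not determined" (no result reported), so its position among the measured compounds is unknown. Its neighbours in the series do have values. In this assay compound 1 `CC(C)(C)OC(=O)NCCNC(=O)CN1CN(c2ccccc2)C2(CCN(C(=O)c3ccc(C(C)(C)C)cc3)CC2)C1=O` gives 10900 nM, and compound 2 `CC(C)(C)c1ccc(C(=O)N2CCC3(CC2)C(=O)N(CC(=O)NCNS(C)(=O)=O)CN3c2ccccc2)cc1` gives 3200 nM. Going by the values given here, the one measured step, a 3.4-fold lower number from compound 1 to compound 2 (0.53 log units; beyond the scatter), alters the chain hanging from the amide-type nitrogen.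

Compound 4 `CCOC(=O)C1CCCN(C(=O)CN2CN(c3ccccc3)C3(CCN(C(=O)c4ccc(C(C)(C)C)cc4)CC3)C2=O)C1` differs from compound 3 in that same region: 3-(ethoxycarbonyl)piperidin-1-yl in place of (3-(methoxycarbonyl)propyl)amino on a carbonyl carbon. Among the compounds with values here, no measured step covers this exchange of an open chain amine for a ring-closed amine, so the size of the step cannot be read from the data; the step from compound 1 to compound 2 only shows that changes on this chain can move the number modestly, and within that range, in either direction.

Compound 4 is therefore expected to land near the measured compounds, with an estimate of 5000 nM in this assay and a range from 1500 nM to 16000 nM.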

Compound 4, half-maximal inhibitory concentration: 8200 nM
For compound 4 the middle estimate is 1.6-fold (0.21 log units) below the measured one, within the range that was stated.
By their numbers in this assay, from the lowest: compound 2; then compounds 4 and 1 (each within the scatter of the next).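

Compound 4 shows that this carbonyl carbon accepts a ring-closed amine, 3-(ethoxycarbonyl)piperidin-1-yl, which has no hydrogen-bond donor, and still gives a measurable number in this assay. Against the open-chain group of the first compound, the ring makes no clear difference, with a 1.3-fold lower number from compound 1 to compound 4 (0.12 log units; within the scatter), while against the methanesulfonamido-bearing chain it gives up some strength, with a 2.6-fold higher number from compound 2 to compound 4 (0.41 log units; beyond the scatter), so that chain remains the best of the measured groups at this position. No measurement given here explains these differences.

Going by these compounds, with no number for compound 3, the direct effect of closing the chain into a ring remains open. Also open, on these data alone, is how much the ethoxycarbonyl group contributes, which a plain piperidine or a piperidine bearing a carboxylic acid could help separate from the contribution of the ring.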